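The compounds below may be only part of what the source reports. "The series", "measured", "known", "first", "only" and "open" are said of these compounds alone.

Compound 1 `O=C1N/C(=N\c2ccc(Cl)cc2)S/C1=C/c1ccccc1O`: > 100000 nM
Compound 2 `CN(C)c1ccc(/C=C2/SC(=Nc3ccc(O)cc3)NC2=O)cc1`: > 100000 nM

Both numbers come from an ADME assay on cells (Homo sapiens) for antiproliferative activity; a higher number here means a weaker inhibitor, a lower number a stronger inhibitor. For compound 1 the value given is a limit of the assay, not a measured number. For compound 2 the value is likewise a limit of the assay. Among the measured compounds shown here, compound 2 stands at the limit of > 100000 nM in this assay, at which 2 of the 2 values shown sit, alongside the only other measured compound. Compound 3 `CN(C)c1ccc(/C=C2/SC(=Nc3ccccc3Cl)NC2=O)cc1` differs from compound 2 by 2-chlorophenyl in place of 4-hydroxyphenyl on a double-bonded nitrogen. For the measured compounds named here, no measured step in this set shows how such a change moves this assay. Compound 3 is expected to remain near the limit, with an expected step that the limit leaves unreadable from compound 2 to compound 3. The estimate for compound 3 is 150000 nM, in a range from 30000 nM to 1000000 nM.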

Compound 3, half-maximal inhibitory concentration: > 100000 nM
Compound 3: a limit, no number; the forecaster's own chance of this, stated with the estimate: 80%; the middle value does not contradict the limit.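

Compound 3 gives a limit, not a number, just as compound 2 does, so no step between compound 2 and compound 3 can be read in this assay: the limit of > 100000 nM in this assay, at which 3 of the 3 values shown sit.

The compounds shown leave open which structural change, if any, would give a measurable value in this assay.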